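Bromine on the Phenyl Ring of Compound 3

This account rests on a few compounds, and the source may have more. Where it says the series, first, only, none or still open, it means among the compounds named here.

Measured so far:
Compound 1 `CC(=O)N1N=C(c2ccco2)CC1c1ccc([N+](=O)[O-])cc1` gives 35800 nM in a functional assay on IMR-32 cells (Homo sapiens) for cytotoxicity, read by sulforhodamine B assay, with a stated time of 48 h; on this read-out higher numbers stand for weaker inhibition and lower numbers for stronger inhibition.
Compound 2 `COc1ccc(C2CC(c3ccco3)=NN2C(C)=O)cc1` gives 14500 nM in this assay.
Compound 3 `O=CCN1N=C(c2ccc3ccccc3c2)CC1c1ccccc1` gives 10000 nM in this assay.

Compound 3 shows the lowest of the three numbers in this assay; its gap to compound 2 lies within the scatter, while its gap to compound 1 lies beyond it. Compound 4 `O=CCN1N=C(c2ccc3ccccc3c2)CC1c1cccc(Br)c1` differs from compound 3 by a single change: bromo in place of hydrogen on an aromatic carbon, on an aromatic carbon of a six-membered aromatic ring of carbon only, meta to a large group. Within the data shown here, the only measured step, a 2.5-fold lower number from compound 1 to compound 2 (0.39 log units; beyond the scatter), concerns another group on another core, so nothing measured bears directly on this change. The step from compound 3 to compound 4 is therefore expected to be no change at the digits printed from compound 3 to compound 4 (within the scatter), nothing beyond the scatter. Compound 4 is expected to give 10000 nM, between 4000 nM and 25000 nM.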

Compound 4, half-maximal inhibitory concentration: 9870 nM
Beside the measured number, compound 4's estimate is 1.0-fold (0.01 log units) above it; the measured number falls inside the stated range.
By their numbers in this assay, from the lowest: compounds 4, 3 and 2 (each within the scatter of the next); then compound 1.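

In this assay, the change from phenyl to 3-bromophenyl gives a 1.0-fold lower number from compound 3 to compound 4 (0.01 log units; within the scatter) and so leaves the number where it stood. The earlier compounds shown here held no single change on this ring, and this one shows that the position takes a bromine atom with no step beyond the scatter. Nothing measured here explains why the number holds.

Going by these compounds, whether an amine or a carboxylic acid at this place would also leave the number unmoved stays open. So does whether bromo would do the same elsewhere on this ring.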